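Swapping the sulfonamide amine on a bromo analogue

The compounds below may be only part of what the source reports. "The series", "measured", "known", "first", "only" and "open" are said of these compounds alone.

Measured so far in a functional assay on the whole organism (strain STD-dd) with Mus musculus as the target, in the maximal electroshock model, with a stated time of 2 h; on this read-out higher numbers stand for an effect only at larger amounts of compound and lower numbers for an effect already at smaller amounts:
compound 1, `CC(C)NS(=O)(=O)Cc1noc2ccc(Cl)cc12`, gives 100 mg/kg;
compound 2, `CN(C)S(=O)(=O)Cc1noc2ccc(Cl)cc12`, gives 57 mg/kg;
compound 3, `CC(C)NS(=O)(=O)Cc1noc2ccc(Br)cc12`, gives 22 mg/kg.

Compound 4, `CN(C)S(=O)(=O)Cc1noc2ccc(Br)cc12`, has not yet been measured. It differs from compound 3 by one change: dimethylamino in place of isopropylamino on a sulfonyl sulfur. The same change has already been seen once, between compound 1 and compound 2: dimethylamino in place of isopropylamino on a sulfonyl sulfur. There it made a 1.8-fold lower number from compound 1 to compound 2 (0.24 log units; within the scatter). The two pairs sit on cores that differ from each other in one place: bromo in place of chloro on an aromatic carbon. That change on its own made a 4.5-fold lower number from compound 1 to compound 3 (0.66 log units; beyond the scatter), and compound 3 stands lowest of the three numbers, with both other compounds beyond the scatter from it. The surroundings of the swapped group are the same in both pairs, word for word.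

Compound 4 is expected to show a 1.7-fold lower number from compound 3 to compound 4 (0.23 log units; within the scatter) in this assay. This expectation rests on the earlier step, because the identical change gave a 1.8-fold lower number from compound 1 to compound 2 (0.24 log units; within the scatter), a step that lies within the scatter. The estimate for compound 4 is 13 mg/kg, with a likely range from 6 mg/kg to 30 mg/kg.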

Compound 4, dose for half-maximal effect: 45 mg/kg
Compound 4: the middle estimate sits 3.5-fold (0.54 log units) below what was measured; the whole stated range lies below it.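

In this assay, dimethylamino in place of isopropylamino on a sulfonyl sulfur did not carry over from the chloro core to the bromo core, where it gave a 2.0-fold higher number from compound 3 to compound 4 (0.31 log units; beyond the scatter): the same change on two cores in this assay, a 1.8-fold lower number (0.24 log units; within the scatter) from compound 1 to compound 2 and a 2.0-fold higher number (0.31 log units; beyond the scatter) from compound 3 to compound 4, 3.6-fold (0.55 log units) apart, beyond the scatter of two such steps Seen from the other side, bromo in place of chloro gave a 1.3-fold lower number from compound 2 to compound 4 (0.10 log units; within the scatter) on the dimethylamino compounds, a smaller step than on the isopropylamino compounds: the same change on two cores in this assay, a 4.5-fold lower number (0.66 log units; beyond the scatter) from compound 1 to compound 3 and a 1.3-fold lower number (0.10 log units; within the scatter) from compound 2 to compound 4, 3.6-fold (0.55 log units) apart, beyond the scatter of two such steps So in these four compounds the outcome of each change depends on the other group present, but a single set of four cannot show why, or whether this holds elsewhere in the series.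

Going by these compounds, it remains open how an unsubstituted amino group or a longer chain such as butylamino on the sulfonyl sulfur would behave on these two cores. On these data alone, it is also open whether fluoro in place of bromo would show the same dependence.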